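A few compounds are considered here, and "the series" means these few. Any claim that something is new, unique, unknown or untested is made for them only; others in the source may bear on it.

Compound 1 `CN1CCN(CCCOc2cccc3nc(Nc4ccc(Cl)c(C(F)(F)F)c4)ccc23)CC1` gives 1440 nM in a functional assay on NCI-H322M cells (Homo sapiens) for inhibition, read by sulforhodamine B assay, with a stated time of 48 h; on this read-out higher numbers stand for weaker inhibition of growth and lower numbers for stronger inhibition of growth.
Compound 2 `CN1CCN(CCCOc2cccc3nc(Nc4ccc(F)c(F)c4)ccc23)CC1` gives 3930 nM in this assay.
Compound 3 `CN1CCN(CCCOc2cccc3nc(Nc4cc(Cl)cc(Cl)c4)ccc23)CC1` gives 1560 nM in this assay.

Compound 3 holds the second highest of the three numbers: its gap to compound 1 lies within the scatter, while the step of a 2.5-fold lower number from compound 2 to compound 3 (0.40 log units; beyond the scatter) is modest and beyond it. Compound 4 `CN1CCN(CCCOc2cccc3nc(Nc4cccc(Cl)c4)ccc23)CC1` differs from compound 3 by hydrogen in place of chloro on an aromatic carbon. Two kinds of step bear on this change: a 1.1-fold higher number from compound 1 to compound 3 (0.03 log units; within the scatter) shows that one exchange of the aryl substituents left the number essentially unchanged, whereas a 2.7-fold higher number from compound 1 to compound 2 (0.44 log units; beyond the scatter) and a 2.5-fold lower number from compound 2 to compound 3 (0.40 log units; beyond the scatter) show that compound 2 sits modestly higher than either of the chloro-bearing compounds. Taking away a chloro is therefore expected to raise the number in this assay modestly, by a 1.9-fold higher number from compound 3 to compound 4 (0.28 log units; within the scatter). Compound 4 is estimated at 3000 nM, with a range from 1200 nM to 8000 nM.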

Compound 4, concentration for 50% growth inhibition: 2670 nM
The estimate for compound 4 lay 1.1-fold (0.05 log units) above the measured number; low and high end bracket the measured number.
By their numbers in this assay, from the lowest: compounds 1, 3, 4 and 2 (each within the scatter of the next, the first and the last beyond it).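

Removing one chloro from the 3,5-dichlorophenyl group gives a 1.7-fold higher number from compound 3 to compound 4 (0.23 log units; within the scatter) and so does not show that this chloro matters for growth inhibition. The 3-chlorophenyl group also fails to separate compound 4 from the other two aryl variants, with a 1.5-fold lower number from compound 2 to compound 4 (0.17 log units; within the scatter) and a 1.9-fold higher number from compound 1 to compound 4 (0.27 log units; within the scatter), even though the gap between compound 1 and compound 2 lies beyond the scatter. No evidence is available to explain this result.

As far as these compounds go, whether a methoxy group, a nitrile or an amine at this position would give a step beyond the scatter remains open. So does the effect of removing the remaining chloro to leave an unsubstituted phenyl.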